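This account rests on a few compounds, and the source may have more. Where it says the series, first, only, none or still open, it means among the compounds named here.

In a functional assay on P388 cells (Mus musculus) for cytotoxicity (a lower number here means a stronger inhibitor, a higher number a weaker inhibitor), compound 1 (`COc1ccc(C[C@H]2C(=O)N[C@@H](C)C(=O)N(C)[C@H]3Cc4ccc(cc4)Oc4cc(ccc4OC)C[C@@H](C(=O)N[C@H](C)C(=O)NC4(SCCS4)C(=O)N2C)N(C)C3=O)cc1`) gives 631 nM, compound 2 (`C[C@@H]1NC(=O)[C@@H](C)NC(=O)[C@@H]2Cc3ccc(O)c(c3)Oc3ccc(cc3)C[C@@H](C(=O)N2C)N(C)C(=O)[C@H](C)NC(=O)[C@H](Cc2ccccc2)N(C)C1=O`) gives 42.7 nM and compound 3 (`CCCN1C(=O)[C@@H](C)NC(=O)[C@@H]2Cc3ccc(OC)c(c3)Oc3ccc(cc3)C[C@@H](C(=O)N2C)N(C)C(=O)[C@H](C)NC(=O)[C@H](Cc2ccc(OC)cc2)N(C)C(=O)[C@@H]1C`) gives 3.98 nM. Compound 3 has the lowest number of the three, beyond the scatter from both others. Compound 4 (`COc1ccc(C[C@H]2C(=O)N[C@@H](C)C(=O)N(C)[C@H]3Cc4ccc(cc4)Oc4cc(ccc4OC)C[C@@H](C(=O)N[C@H](C)C(=O)N(C/C=C(\C)CCC=C(C)C)[C@@H](C)C(=O)N2C)N(C)C3=O)cc1`) departs from compound 3 by one change: 2,6-dimethylhepta-1,5-dien-1-yl in place of ethyl on a saturated chain carbon bound to an amide-type nitrogen in a ring. This places 2,6-dimethylhepta-1,5-dien-1-yl in place of ethyl on a saturated chain carbon bound to an amide-type nitrogen in a ring. Among the compounds with values here, no measured pair isolates a change at this place, so the expectation is a judgement resting on compound 3 at 3.98 nM. A weaker result beyond the scatter is expected in this assay, with an estimated 8.8-fold higher number from compound 3 to compound 4 (0.94 log units; beyond the scatter). The estimate for compound 4 is 35 nM, with an expected range from 7 nM to 200 nM.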

Compound 4, half-maximal inhibitory concentration: 49 nM
Beside the measured number, compound 4's estimate is 1.4-fold (0.15 log units) below it; the range from low to high includes it.
By their numbers in this assay, from the lowest: compound 3; then compounds 2 and 4 (each within the scatter of the next); then compound 1.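

In this assay, 2,6-dimethylhepta-1,5-dien-1-yl in place of ethyl on a saturated chain carbon bound to an amide-type nitrogen in a ring gives a 12-fold higher number from compound 3 to compound 4 (1.09 log units; beyond the scatter). This position is therefore sensitive to this change, yet the larger group, with 9 heavy atoms against 2, does not abolish cytotoxicity: compound 4 still gives 49 nM. No available data bear on the reason for the loss.

On these data alone, whether the loss follows chain size or the 2 double bonds remains open. A saturated chain such as octyl would separate the two.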